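Moving a Methoxy Group on the Phenoxy Ring

This account rests on a few compounds, and the source may have more. Where it says the series, first, only, none or still open, it means among the compounds named here.

Compound 1 `COc1ccc(Oc2ccc3c(NCCCNCc4cc(F)ccc4OC)ccnc3c2)cc1`: 14500 nM
Compound 2 `CC(C)Cc1ccc2c(NCCCNCc3ccco3)ccnc2c1`: 4200 nM
Compound 3 `c1ccc(-c2ccc3c(NCCCNCc4ccco4)ccnc3c2)cc1`: 32000 nM

In a physicochemical assay for solubility, with a stated time of 18 h, at pH 7.4 (a lower number here means a less soluble compound, a higher number a more soluble compound), compound 1 stands second highest of the three numbers: compound 3 gives a higher value and compound 2 a lower one. Compound 4 `COc1cccc(Oc2ccc3c(NCCCNCc4cc(F)ccc4OC)ccnc3c2)c1` keeps the same atoms as compound 1, joined differently: 3-methoxyphenyl in place of 4-methoxyphenyl on an oxygen on an aromatic ring. Among the compounds with values here, the one measured step, a 7.6-fold higher number from compound 2 to compound 3 (0.88 log units; beyond the scatter), alters a different part of the shared core, so it does not bear on the change from 4-methoxyphenoxy to 3-methoxyphenoxy, and nothing measured speaks to that change directly. The step in this assay is therefore expected to stay within the usual scatter, in no clear direction, giving a 1.0-fold lower number from compound 1 to compound 4 (0.02 log units; within the scatter). Compound 4 is estimated at 14000 nM, with a range from 7000 nM to 28000 nM.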

Compound 4, solubility: 14500 nM
Compound 4: middle estimate off by 1.0-fold (0.02 log units), on the low side; the range from low to high includes it.
By their numbers in this assay, from the lowest: compound 2; then compounds 1 and 4 (each within the scatter of the next); then compound 3.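

In this assay, putting 3-methoxyphenyl in place of 4-methoxyphenyl on the oxygen gives no change at the digits printed from compound 1 to compound 4 (within the scatter). Within the data shown here, this is the first measured change at this position, and it shows that rearranging these same atoms leaves the read-out where it was. Nothing measured here offers a reason for this result. This single pair says nothing about changes of another kind at this position. Going by these compounds, whether an amine or a carboxylic acid in place of the methoxy group would shift the number remains open.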